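From a Hydroxypropyl Amide to an Imidazolyl Amide

This account rests on a few compounds, and the source may have more. Where it says the series, first, only, none or still open, it means among the compounds named here.

Compound 1, `O=C(NCCO)c1cccc2[nH]c(-c3ccncc3)nc12`: 498 uM
Compound 2, `COc1ccc(-c2nc3c(C(=O)NCCCO)cccc3[nH]2)cc1OC`: 46 uM
Compound 3, `COc1ccc(-c2nc3c(C(=O)NCCCO)cccc3[nH]2)c(OC)c1OC`: 40 uM

Of the compounds shown here, three have been measured in an ADME assay on Vero cells (Chlorocebus sabaeus) for cytotoxicity; on this read-out higher numbers stand for lower toxicity in this test and lower numbers for higher toxicity in this test. Compound 2 gives 46 uM, the second highest of the three numbers. Compound 3 gives 40 uM, which lies within the scatter of compound 2, while compound 1 gives 498 uM, a higher number that lies beyond the scatter.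

Compound 4, `COc1ccc(-c2nc3c(C(=O)Nc4c[nH]cn4)cccc3[nH]2)cc1OC`, has not yet been measured. It differs from compound 2 by 1H-imidazol-4-yl in place of 3-hydroxypropyl on an amide-type nitrogen. Going by the values given here, the only measured single-point step, a 1.2-fold lower number from compound 2 to compound 3 (0.06 log units; within the scatter), alters an aromatic substituent and leaves the amide untouched, so no measured step bears directly on this change. With nothing pointing either way, compound 4 is expected to show a step of a 1.1-fold higher number from compound 2 to compound 4 (0.04 log units; within the scatter). Compound 4 is therefore expected to give 50 uM, with a range from 20 uM to 150 uM.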

Compound 4, half-maximal toxic concentration: 306 uM
Compound 4: the middle estimate sits 6.1-fold (0.79 log units) below what was measured; measured number outside the range, above it.
By their numbers in this assay, from the lowest: compounds 3 and 2 (each within the scatter of the next); then compounds 4 and 1 (each within the scatter of the next).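

In this assay, placing 1H-imidazol-4-yl instead of 3-hydroxypropyl on the amide-type nitrogen gives a 6.7-fold higher number from compound 2 to compound 4 (0.82 log units; beyond the scatter), so this position can shift the read-out beyond the scatter towards lower toxicity in this test. The earlier step, a 1.2-fold lower number from compound 2 to compound 3 (0.06 log units; within the scatter), changed an aromatic substituent instead and left the amide untouched. Nothing measured here accounts for the shift.

The compounds shown leave open whether the ring or the loss of the hydroxyl group drives this step. They also leave open whether a phenyl ring or a longer chain ending in an amine on the same nitrogen would give a similar number.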